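Working notes on the anilino swap from compound 3 to compound 4

This account rests on a few compounds, and the source may have more. Where it says the series, first, only, none or still open, it means among the compounds named here.

Compound 1 `FC(F)(F)c1ccc(CSc2nc(Nc3ccccc3)c3ccccc3n2)cc1` gives 18400 nM in a functional assay on MDA-MB-231 cells (Homo sapiens) for cytotoxicity, read by MTT assay, with a stated time of 72 h; on this read-out lower numbers stand for stronger inhibition and higher numbers for weaker inhibition. Compound 2 `Cc1ccccc1Nc1nc(SCc2ccc(C(F)(F)F)cc2)nc2ccccc12` gives 27100 nM in this assay, and compound 3 `O=[N+]([O-])c1cccc(Nc2nc(SCc3ccc(C(F)(F)F)cc3)nc3ccccc23)c1` gives 31500 nM. Compound 3 carries the highest of the three numbers, yet the steps of a 1.7-fold higher number from compound 1 to compound 3 (0.23 log units; within the scatter) and a 1.2-fold higher number from compound 2 to compound 3 (0.07 log units; within the scatter) both sit within the scatter, as does a 1.5-fold higher number from compound 1 to compound 2 (0.17 log units; within the scatter). Compound 4 `Fc1ccc(Nc2nc(SCc3ccc(C(F)(F)F)cc3)nc3ccccc23)cc1` differs from compound 3 by 4-fluorophenyl in place of 3-nitrophenyl on a nitrogen on an aromatic ring. For the measured compounds named here, every measured step that touches the ring on the nitrogen lies within the scatter, and no measured pair isolates a fluorine on that ring, so nothing here points to a move in this assay beyond the scatter in either direction. Compound 4 is therefore expected to give 22000 nM, within 9000 nM to 50000 nM, an expected step of a 1.4-fold lower number from compound 3 to compound 4 (0.16 log units; within the scatter) that should stay within the scatter.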

Compound 4, half-maximal inhibitory concentration: 15000 nM
Beside the measured number, compound 4's estimate is 1.5-fold (0.17 log units) above it, within the range that was stated.
By their numbers in this assay, from the lowest: compounds 4, 1, 2 and 3 (each within the scatter of the next, the first and the last beyond it).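

In this assay, for the compounds shown here, the step of a 2.1-fold lower number from compound 3 to compound 4 (0.32 log units; beyond the scatter) is the first at this place to pass beyond the scatter, though only modestly. The steps of a 1.8-fold lower number from compound 2 to compound 4 (0.26 log units; within the scatter) and a 1.2-fold lower number from compound 1 to compound 4 (0.09 log units; within the scatter) stay within it, so 4-fluorophenyl separates only from 3-nitrophenyl and not from the other two groups on the nitrogen. Nothing available bears on the cause of this separation.

As far as these compounds go, whether a phenyl ring carrying an amine or a carboxylic acid, in place of 4-fluorophenyl, would move the number further in either direction remains open.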